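The compounds below may be only part of what the source reports. "The series", "measured", "known", "first", "only" and "open" are said of these compounds alone.

Compound 1 `O=S(=O)(NCCCNc1nccc(-c2c(-c3cccc(F)c3)nc3sccn23)n1)c1ccc(C(F)(F)F)cc1`: 11700 nM
Compound 2 `O=S(=O)(NCCNc1nccc(-c2c(-c3cccc(F)c3)nc3sccn23)n1)c1ccc(Cl)cc1`: 18600 nM
Compound 3 `COc1ccc(S(=O)(=O)NCCCNc2nccc(-c3c(-c4cccc(F)c4)nc4sccn34)n2)cc1`: 8980 nM

All three share one core and differ only at the far end of the chain, on the ring attached to the sulfonyl group. In a functional assay on SK-MEL-28 cells (Homo sapiens) for cytotoxicity, read by MTT assay (a higher number here means a weaker inhibitor, a lower number a stronger inhibitor), compound 2 gives the highest of the three numbers; compound 1 sits within the scatter of it, while compound 3 lies beyond the scatter. Among the measured compounds shown here, the one measured step on that ring, a 1.3-fold lower number from compound 1 to compound 3 (0.11 log units; within the scatter), stayed within the scatter, so changing the group there moved the number little.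

Compound 4 `O=S(=O)(NCCNc1nccc(-c2c(-c3cccc(F)c3)nc3sccn23)n1)c1ccccc1` is compound 2 with hydrogen in place of chloro on an aromatic carbon. For the measured compounds named here, only that step bears on this change, and it was small, so the expected step is a 1.1-fold lower number from compound 2 to compound 4 (0.04 log units; within the scatter), without clear direction. Compound 4 is therefore estimated at 17000 nM, within 8000 nM to 38000 nM.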

Compound 4, half-maximal inhibitory concentration: 19000 nM
Beside the measured number, compound 4's estimate is 1.1-fold (0.05 log units) below it; the measured number falls inside the stated range.
By their numbers in this assay, from the lowest: compounds 3, 1, 2 and 4 (each within the scatter of the next, the first and the last beyond it).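

In this assay, replacing chloro with hydrogen gives a 1.0-fold higher number from compound 2 to compound 4 (0.01 log units; within the scatter). The earlier step swapped one group for another on the ring, whereas this one leaves the ring with no added group at all, and the number still holds. On the chain of compound 2, then, the chloro makes no measurable difference to the reading. Nothing measured here offers a reason for this. Still open, on these data alone, is whether an amine or a carboxylic acid at this place would move the number, and whether the same change would read alike on the longer chain of compound 1.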